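Nitro to carboxy on the core of compound 1

This account rests on a few compounds, and the source may have more. Where it says the series, first, only, none or still open, it means among the compounds named here.

- compound 1 `Cc1nn(-c2ccccc2)c(Oc2ccc(-c3nc4cc([N+](=O)[O-])ccc4[nH]3)cc2)c1/C=N/Nc1ccccc1` gives 58500 nM
- compound 2 `Cc1nn(-c2ccccc2)c(Oc2ccc(-c3nc4cc([N+](=O)[O-])ccc4[nH]3)cc2)c1/C=N/NC(N)=S` gives 22500 nM

In a functional assay on HepG2 cells (Homo sapiens) for cytotoxicity, read by sulforhodamine B assay, with a stated time of 48 h (on this read-out higher numbers stand for weaker inhibition of growth and lower numbers for stronger inhibition of growth), compound 1 stands at 58500 nM as the higher of the two numbers, and the nearest neighbour in the measured set is compound 2 at 22500 nM. Compound 3 `Cc1nn(-c2ccccc2)c(Oc2ccc(-c3nc4cc(C(=O)O)ccc4[nH]3)cc2)c1/C=N/Nc1ccccc1` is not yet measured. It differs from compound 1 as follows: carboxy in place of nitro on an aromatic carbon with carboxy in place of nitro on an aromatic carbon of the shared core.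

Among the compounds with values here, only one measured step is available, and it bears on this change indirectly. That step, a 2.6-fold lower number from compound 1 to compound 2 (0.41 log units; beyond the scatter), is modest and lies beyond the scatter, but it concerns the group on an amine nitrogen and leaves the nitro group untouched. Within the data shown here, no measured pair changes the nitro group, so the data give no direction for this swap. A modest step of similar size or smaller is expected in this assay, with little confidence in its sign. The estimate amounts to an expected 1.2-fold lower number from compound 1 to compound 3 (0.07 log units; within the scatter) within a wide range. The estimated value for compound 3 is 50000 nM with an expected range from 20000 nM to 110000 nM on present data.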

Compound 3, concentration for 50% growth inhibition: 37200 nM
For compound 3 the middle estimate is 1.3-fold (0.13 log units) above the measured one, within the range that was stated.
By their numbers in this assay, from the lowest: compounds 2, 3 and 1 (each within the scatter of the next, the first and the last beyond it).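

Within the data shown here, this is the first measured change at this aromatic carbon of the shared core. In this assay, carboxy in place of nitro gives (a 1.6-fold lower number from compound 1 to compound 3 (0.20 log units; within the scatter)), so compound 1 and compound 3 cannot be told apart, and here nitro can be exchanged for carboxy without a difference that exceeds the usual scatter. Among these compounds, this contrasts with the change on the amine nitrogen (a 2.6-fold lower number from compound 1 to compound 2 (0.41 log units; beyond the scatter)), the only measured step so far that lies beyond the scatter, although a single pair at each place shows no general rule. Nothing measured explains why the nitro and carboxy compounds read alike.

The compounds shown leave open whether an amine, a methyl ester or a primary amide on this aromatic carbon would also stay within the scatter of compound 1. They also leave open whether carboxy in place of nitro would give a similar step when the group on the amine nitrogen is the one carried by compound 2, since that combination is not among the compounds shown here.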